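Swapping Chlorine for Bromine on the Sulfonamide Arm

The source may hold more compounds than are shown below. What is called first, only, known or untested is meant among the compounds shown, and "the series" means these compounds.

Among the compounds with values here, compound 3 `CC(C)=CCC/C(C)=C/CC1Cc2c(OCCCNS(=O)(=O)c3ccc(Cl)cc3)cc(=O)n(CCCO)c2CC1(C)C` gives the highest inhibition number of the three compounds measured so far in a functional assay on PANC-1 cells (Homo sapiens) for inhibition, read by MTT assay, with a stated time of 24 h, tested at 10 uM; on this read-out higher numbers stand for more inhibition at the one concentration tested (going by the name of the read-out) and lower numbers for less inhibition. In this assay compound 3 gives 16.1%. Compound 1 `CC(C)=CCC1Cc2c(OCCCNS(=O)(=O)c3ccc(Br)cc3)cc(=O)n(CCCO)c2CC1(C)C`, which already carries a (4-bromophenyl)sulfonyl group but a different unsaturated side chain on the shared core, gives 3.7%. Compound 2 `CCOc1cc(=O)n(CCCO)c2c1CC(C/C=C(\C)CCC=C(C)C)C(C)(C)C2`, which has no sulfonamide arm at all, gives 0.8%. Within the data shown here, the only step measured directly, a number 15.3 percentage points higher from compound 2 to compound 3 (beyond the scatter), shows that adding the ((4-chlorophenyl)sulfonyl)amino group raises inhibition.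

Compound 4 `CC(C)=CCC/C(C)=C/CC1Cc2c(OCCCNS(=O)(=O)c3ccc(Br)cc3)cc(=O)n(CCCO)c2CC1(C)C` differs from compound 3 in one place: bromo in place of chloro on an aromatic carbon. Among the measured compounds shown here, no measured step exchanges chlorine for bromine, so nothing bears directly on this move. Compound 1 and compound 3 do carry the two different halogens, but they also differ in the side chain, so their values cannot be read as a halogen comparison. Because a number 15.3 percentage points higher from compound 2 to compound 3 (beyond the scatter) tells only that the whole sulfonamide arm counts, the halogen swap alone is expected to shift the read-out little, if at all beyond the scatter. Compound 4 is therefore expected to give 14%, with a likely range from 4% to 26%. The step this estimate implies, a number 2.1 percentage points lower from compound 3 to compound 4 (within the scatter), is expected to be small.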

Compound 4, a percentage reported as inhibition, at one concentration (the size of the read-out at that concentration, not a potency): 0%
Compound 4: the middle estimate sits 14 percentage points above what was measured, outside the stated range (below it).
By their numbers in this assay, from the lowest: compounds 4, 2 and 1 (each within the scatter of the next); then compound 3.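

In this assay, the halogen on this aromatic carbon, para to a large group, turns out to count on its own: with everything else held fixed, bromo in place of chloro gives a number 16.1 percentage points lower from compound 3 to compound 4 (beyond the scatter). The rise seen with the sulfonamide arm therefore cannot be credited to the arm as a whole, since the bromo version gives only a number 0.8 percentage points lower from compound 2 to compound 4 (within the scatter), while the chloro version gives a number 15.3 percentage points higher from compound 2 to compound 3 (beyond the scatter). With bromo in place, the longer side chain also makes no clear difference, at a number 3.7 percentage points lower from compound 1 to compound 4 (within the scatter), so among these compounds only the chloro arm on the longer side chain stands out, and nothing shown explains why exchanging one halogen atom for another has this effect.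

Going by these compounds, whether fluoro, methoxy or a plain hydrogen on that ring carbon would read like chloro or like bromo stays open. Also open, on these data alone, are whether chloro would stand out on the side chain of compound 1 and, with every number taken at a single concentration, how these compounds compare in potency.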